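Methoxy in place of fluoro on compound 3

The source may report more compounds than this note shows. Statements on the series, on what has been measured and on what is new or still open speak of the compounds shown alone.

Measured so far in a functional assay on PC-3 cells (Homo sapiens) for inhibition, read by MTT assay, with a stated time of 48 h; on this read-out lower numbers stand for stronger inhibition and higher numbers for weaker inhibition:
compound 1, `COc1cc(N(Cc2ccc(Cl)cc2)S(=O)(=O)c2ccc(C)cc2)cc(OC)c1OC`, gives 14600 nM;
compound 2, `COc1cc(N(Cc2nc3ccccc3[nH]2)S(=O)(=O)c2ccccc2Cl)cc(OC)c1OC`, gives 34500 nM;
compound 3, `Cc1ccc(S(=O)(=O)N(Cc2nc3ccccc3[nH]2)c2ccc(F)cc2)cc1`, gives 45000 nM.

Compound 3 stands with the highest number of the three. Compound 2 sits within the scatter of compound 3, so the two cannot be ordered; compound 1 has a number well beyond the scatter below compound 3.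

Compound 4, `COc1ccc(N(Cc2nc3ccccc3[nH]2)S(=O)(=O)c2ccc(C)cc2)cc1`, differs from compound 3 only by methoxy in place of fluoro on an aromatic carbon. Among the compounds with values here, no measured pair shows this change, so its size and direction in this assay are unknown; the expectation is a step no larger than the scatter, in no set direction, giving a 1.1-fold lower number from compound 3 to compound 4 (0.05 log units; within the scatter). Compound 4 is therefore estimated at 40000 nM, between 13000 nM and 120000 nM.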

Compound 4, half-maximal inhibitory concentration: > 50000 nM
Compound 4 ended at the assay's limit (the forecaster's own chance of this, stated with the estimate: 15%); at least 1.2-fold (0.09 log units) between middle value and limit.
By their numbers in this assay, from the lowest: compound 1; then compounds 2 and 3 (each within the scatter of the next). At a limit, above all of these: compound 4.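

In this assay compound 4 gives > 50000 nM, which is a limit of the assay and not a number. On these data alone, the change from 4-fluorophenyl to 4-methoxyphenyl gives an at least 1.1-fold higher number from compound 3 to compound 4 (0.04 log units; that floor lies within the scatter), so methoxy at this position brings no lower number, although the true size of the step stays unknown. Compound 4 is the only compound shown that reaches this limit: the limit of > 50000 nM in this assay, at which 1 of the 4 values shown sits.

As far as these compounds go, whether an amine or a carboxylic acid in this place would give a lower number stays open, as does the outcome of the same change on the core of compound 1.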